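The compounds below may be only part of what the source reports. "The series", "measured", "known", "first", "only" and "open" are said of these compounds alone.

Three compounds sharing one core were tested in a functional assay on HCT-116 cells (Homo sapiens) for cytotoxicity, read by sulforhodamine B assay, with a stated time of 72 h; a higher number here means a weaker inhibitor, a lower number a stronger inhibitor: compound 1 (`Cc1ccc(-c2cc(C(=O)Nc3ccncc3)nn2-c2ccc3ccccc3n2)cc1`), compound 2 (`Cc1ccc(-c2cc(C(=O)Nc3ccc(Cl)nc3Cl)nn2-c2ccc3ccccc3n2)cc1`) and compound 3 (`Cc1ccc(-c2cc(C(=O)Nc3ccnc(Cl)c3)nn2-c2ccc3ccccc3n2)cc1`). Compound 1 gives 8100 nM and compound 2 gives 7900 nM, and a 1.0-fold lower number from compound 1 to compound 2 (0.01 log units; within the scatter) separates them by no more than the scatter. Compound 3, at 1100 nM, has the lowest number of the three and is the strongest inhibitor among them, standing apart through a 7.4-fold lower number from compound 1 to compound 3 (0.87 log units; beyond the scatter) and a 7.2-fold lower number from compound 2 to compound 3 (0.86 log units; beyond the scatter).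

Compound 4 (`COc1ncccc1NC(=O)c1cc(-c2ccc(C)cc2)n(-c2ccc3ccccc3n2)n1`) has 2-methoxypyridin-3-yl in place of 2-chloropyridin-4-yl on an amide-type nitrogen. For the measured compounds named here, no measured compound carries the entering group, so the evidence is indirect. The group that leaves belongs to compound 3 alone, and both modest steps to compound 3, a 7.4-fold lower number from compound 1 to compound 3 (0.87 log units; beyond the scatter) and a 7.2-fold lower number from compound 2 to compound 3 (0.86 log units; beyond the scatter), ended in that group. Three compounds establish no rule, but giving up that group is expected to undo much of such a step, moving the number back towards the other two compounds. A higher number is therefore expected, with the size estimated as a 3.6-fold higher number from compound 3 to compound 4 (0.56 log units; beyond the scatter). For compound 4 the estimated value is 4000 nM, with an expected range from 1200 nM to 12000 nM.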

Compound 4, half-maximal inhibitory concentration: 15700 nM
Compound 4: the middle estimate sits 3.9-fold (0.59 log units) below what was measured, outside the stated range (above it).
By their numbers in this assay, from the lowest: compound 3; then compounds 2, 1 and 4 (each within the scatter of the next).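

In this assay, the step of a 14-fold higher number from compound 3 to compound 4 (1.15 log units; beyond the scatter) is the only one in the set graded large, and it shows how much rests on 2-chloropyridin-4-yl at this place on the amide-type nitrogen. Compound 4 does not go beyond the two weaker compounds, as the step of a 2.0-fold higher number from compound 2 to compound 4 (0.30 log units; within the scatter) and the step of a 1.9-fold higher number from compound 1 to compound 4 (0.29 log units; within the scatter) both stay within the scatter, so 2-methoxypyridin-3-yl, 2,6-dichloropyridin-3-yl and pyridin-4-yl now share one level, while 2-chloropyridin-4-yl alone stands apart from it. Nothing given here explains why that one group stands apart.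

Going by these compounds, it remains open whether the lower number of compound 3 depends on the chloro group itself or on the whole 2-chloropyridin-4-yl group, and a 2-methoxypyridin-4-yl or 2-bromopyridin-4-yl group on this nitrogen would help to separate the two readings. On these data alone, it is also open whether the shared level of compounds 1, 2 and 4 belongs to pyridinyl groups in general, which a plain phenyl or 3-chlorophenyl group at the same place could test.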